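A few compounds are considered here, and "the series" means these few. Any claim that something is new, unique, unknown or untested is made for them only; others in the source may bear on it.

Measured compounds in an assay on isolated protein for inhibition of thyroid hormone receptor alpha (Homo sapiens), read by fluorescence polarization; on this read-out higher numbers stand for weaker inhibition and lower numbers for stronger inhibition:

Compound 1 `CS(=O)(=O)c1ccc(C(=O)N2CCC(C(=O)N3CCc4ccccc4C3)CC2)cc1[N+](=O)[O-]` gives > 60000 nM, a limit of this assay.
Compound 2 `CC(C)N(C(=O)C1CCN(C(=O)c2ccc(S(C)(=O)=O)c([N+](=O)[O-])c2)CC1)C(C)C` gives > 60000 nM, a limit of this assay.
Compound 3 `CN(Cc1ccccc1F)C(=O)C1CCN(C(=O)c2ccc(S(C)(=O)=O)c([N+](=O)[O-])c2)CC1` gives > 60000 nM, a limit of this assay.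

Compound 3 therefore stands at the limit of this assay, with no number of its own, and both other compounds stand at the same limit (the limit of > 60000 nM in this assay, at which 3 of the 3 values shown sit). The measured steps between them, a step that the two limits leave unreadable from compound 1 to compound 2, a step that the two limits leave unreadable from compound 1 to compound 3 and a step that the two limits leave unreadable from compound 2 to compound 3, are all unreadable in size and direction, since every value involved is a limit.

Compound 4 `CC1Cc2ccccc2N1C(=O)C1CCN(C(=O)c2ccc(S(C)(=O)=O)c([N+](=O)[O-])c2)CC1` differs from compound 3 by 2-methyl-2,3-dihydro-1H-indol-1-yl in place of (2-fluorobenzyl)(methyl)amino on a carbonyl carbon. Going by the values given here, the steps that bear on this change are the three above, and none of them gives a readable size: three different amide substituents on the same carbonyl carbon all leave the compound at the limit (the limit of > 60000 nM in this assay, at which 3 of the 3 values shown sit). No direction can be taken from them. The expectation for the step of a number no higher from compound 3 to compound 4 (the limit leaves the size open) is therefore no readable change beyond the scatter, with compound 4 most likely also reported only as a limit in this assay. Compound 4 is estimated at 60000 nM, with a range from 20000 nM to 200000 nM.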

Compound 4, half-maximal inhibitory concentration: > 60000 nM
Compound 4: no number, only a limit; the forecaster's own chance of this, stated with the estimate: 85%; the middle value lies on the limit itself.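

In this assay compound 4 gives > 60000 nM, a limit and not a number, and its steps from compounds 1, 2 and 3 cannot be read: the limit of > 60000 nM in this assay, at which 4 of the 4 values shown sit.

The compounds shown leave open whether any substituent on this carbonyl carbon gives a readable number, and how compounds 1, 2, 3 and 4 rank against one another.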